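This account rests on a few compounds, and the source may have more. Where it says the series, first, only, none or still open, it means among the compounds named here.

Series notes, thioether chain on the shared core. Compound 1 `Cc1ccccc1CSc1n[nH]c(-n2[se]c3ccccc3c2=O)n1` in a functional assay on SMMC-7721 cells (Homo sapiens) for antiproliferative activity, read by CCK-8 assay, with a stated time of 48 h (on this read-out higher numbers stand for weaker inhibition and lower numbers for stronger inhibition), gives 36200 nM. Compound 2 `CCCCCSc1n[nH]c(-n2[se]c3ccccc3c2=O)n1` in this assay gives 31400 nM, so compound 2 sits beside compound 1 with a difference inside the usual scatter: a 1.2-fold lower number from compound 1 to compound 2 (0.06 log units; within the scatter). For the measured compounds named here, that single step, which swaps one chain for another on the carbon bound to the sulfur, is the only measured change in this part of the molecule, and it moved nothing.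

Compound 3 `CCCSc1n[nH]c(-n2[se]c3ccccc3c2=O)n1` is the next member and shortens the chain: hydrogen in place of ethyl on a saturated chain carbon, three bonds along the chain from a sulfur. Going by the values given here, the only step that bears on it is the one from compound 1 to compound 2, which stayed within the scatter, so no step beyond the scatter is expected in this assay in either direction. The expected step is therefore a 1.1-fold higher number from compound 2 to compound 3 (0.03 log units; within the scatter). For compound 3 the estimate in this assay is 34000 nM, with a range from 15000 nM to 80000 nM.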

Compound 3, half-maximal inhibitory concentration: 6020 nM
Compound 3: the middle estimate sits 5.6-fold (0.75 log units) above what was measured; measured number outside the range, below it.
By their numbers in this assay, from the lowest: compound 3; then compounds 2 and 1 (each within the scatter of the next).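

In this assay the chain on the sulfur turns out not to be silent: hydrogen in place of ethyl, three bonds along the chain from the sulfur, gives a 5.2-fold lower number from compound 2 to compound 3 (0.72 log units; beyond the scatter) and leaves compound 3, with its propyl chain, with the lowest number of the three. Ethyl in place of 2-methylphenyl on the saturated chain carbon bound to the sulfur gives a 6.0-fold lower number from compound 1 to compound 3 (0.78 log units; beyond the scatter), so the flat step between compound 1 and compound 2 did not mean that this position tolerates any change without effect. Nothing available here accounts for the shift.

On these data alone, whether a methyl or ethyl chain on the sulfur would lower the number further remains open, so the propyl chain cannot yet be called an optimum. Also open, as far as these compounds go, is how an amine or a carboxylic acid in place of the propyl chain would read.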